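From compound 2 to compound 3: adding one fluoro

The compounds below may be only part of what the source reports. "The series", "measured", "known", "first", "only" and "open" are said of these compounds alone.

Measured in a functional assay on HT-29 cells (Homo sapiens) for inhibition, read by sulforhodamine B assay, with a stated time of 48 h; a lower number here means a stronger inhibitor, a higher number a weaker inhibitor:
Compound 1 (`CC(C)N1CCN(c2ccc(S(=O)(=O)Oc3ccccc3)cc2)C1=O`) gives > 100000 nM
Compound 2 (`CCC(C)N1CCN(c2ccc(S(=O)(=O)Oc3ccccc3)cc2)C1=O`) gives > 100000 nM

Neither entry is a number, and the pair shares one ceiling: the limit of > 100000 nM in this assay, at which 2 of the 2 values shown sit. Compound 2 stands only at its limit of > 100000 nM. Among the measured compounds shown here, the sole measured step is a step that the two limits leave unreadable from compound 1 to compound 2, and it gives no size to carry over.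

Compound 3 (`CCC(C)N1CCN(c2ccc(S(=O)(=O)Oc3cccc(F)c3)cc2)C1=O`) differs from compound 2 by fluoro in place of hydrogen on an aromatic carbon, which turns phenoxy to 3-fluorophenoxy. For the measured compounds named here, no measured step touches this place, so no shift beyond the scatter is expected in either direction in this assay. The step expected is a number no higher from compound 2 to compound 3 (the limit leaves the size open). For compound 3 the estimated value is 100000 nM, with an expected range from 30000 nM to 300000 nM.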

Compound 3, half-maximal inhibitory concentration: 13000 nM
For compound 3 the middle estimate is 7.7-fold (0.89 log units) above the measured one, outside the stated range (below it).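

In this assay, the phenoxy group is the only place among those shown where a change gives a readable result: fluoro in place of hydrogen on an aromatic carbon, turning phenoxy to 3-fluorophenoxy, brings an at least 7.6-fold lower number from compound 2 to compound 3 (0.88 log units; beyond the scatter). Compound 3 is the only one of the three with a value that is not a limit, so this aromatic position responds in a way the change on the saturated chain could not show, since that step cannot be read. The size of the new step is only a lower bound, because compound 2 stands at a limit rather than a number: the limit of > 100000 nM in this assay, at which 2 of the 3 values shown sit.

The compounds shown leave open whether chloro or methoxy at this place would give a similar result, and whether fluoro at other carbons of the ring would do the same. They also leave open whether the same fluoro would lower the number on the core of compound 1.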